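From Oxolanyl to Dioxolanyl on a Shared Core

The compounds below may be only part of what the source reports. "The series", "measured", "known", "first", "only" and "open" are said of these compounds alone.

In a functional assay on A-375 cells (Homo sapiens) for cytotoxicity, read by MTT assay, with a stated time of 72 h (a lower number here means a stronger inhibitor, a higher number a weaker inhibitor), three compounds built on a shared core have been measured. Compound 1 (`CN(C)CCCCCn1c2c(c3ccccc31)C(=O)c1c[n+]([O-])c3ccccc3c1C2=O`) gives 560 nM, compound 3 (`O=C1c2c[n+]([O-])c3ccccc3c2C(=O)c2c1c1ccccc1n2CCCCN1CCNCC1`) gives 460 nM and compound 2 (`O=C1c2c[n+]([O-])c3ccccc3c2C(=O)c2c1c1ccccc1n2Cc1cn([C@H]2O[C@H](CO)[C@@H](O)[C@H]2O)nn1`) gives 340 nM. Compound 2 therefore stands within the scatter of both others, and the three cannot be ranked.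

The next compound, compound 4 (`CC1(C)O[C@@H](CO)[C@H](Cn2cc(Cn3c4c(c5ccccc53)C(=O)c3c[n+]([O-])c5ccccc5c3C4=O)nn2)O1`), differs from compound 2 in one place, on an aromatic nitrogen of a five-membered aromatic ring with 3 nitrogen: (5-(hydroxymethyl)-2,2-dimethyl-1,3-dioxolan-4-yl)methyl in place of 3,4-dihydroxy-5-(hydroxymethyl)oxolan-2-yl on an aromatic nitrogen. For the measured compounds named here, no measured step changes a group at this place. Going by the values given here, the only single-place step available is a 1.2-fold lower number from compound 1 to compound 3 (0.09 log units; within the scatter), with piperazin-1-yl in place of (dimethylamino)methyl on a saturated chain carbon. It bears on the question only indirectly. Even so, compound 1 at 560 nM and compound 2 at 340 nM stay within the scatter of each other although they carry very different groups on the shared core. The data give no direction for the change, so no shift beyond the scatter is expected. The expected step is a 1.2-fold higher number from compound 2 to compound 4 (0.09 log units; within the scatter). Compound 4 is estimated at 420 nM, with an expected range from 170 nM to 1000 nM.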

Compound 4, half-maximal inhibitory concentration: 190 nM
Beside the measured number, compound 4's estimate is 2.2-fold (0.34 log units) above it; the range from low to high includes it.
By their numbers in this assay, from the lowest: compounds 4, 2, 3 and 1 (each within the scatter of the next, the first and the last beyond it).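

In this assay, for the compounds shown here, the only measured step on an aromatic nitrogen of a five-membered aromatic ring with 3 nitrogen is a 1.8-fold lower number from compound 2 to compound 4 (0.25 log units; within the scatter), so this exchange of (5-(hydroxymethyl)-2,2-dimethyl-1,3-dioxolan-4-yl)methyl for 3,4-dihydroxy-5-(hydroxymethyl)oxolan-2-yl does not move the result beyond the scatter. The two groups differ clearly in what is counted: the entering group has 1 hydrogen-bond donor against 3, 3 hydrogen-bond acceptors against 4, and 2 defined stereocentres against 4, and it has two hetero atoms in its ring rather than one, yet compound 2 and compound 4 cannot be told apart here. No independent measurement is available that would account for the size of this step.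

Since these differences all arrive together in a single step, the compounds shown do not separate the contribution of any one of them. On these data alone, it also remains open whether a quite different group on this nitrogen, such as a primary amine, a carboxylic acid or a plain hexyl chain, would give a step beyond the scatter.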